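Ring-nitrogen substituent variation on the sulfonamide series

This account rests on a few compounds, and the source may have more. Where it says the series, first, only, none or still open, it means among the compounds named here.

Compound 3 `CC(C)(O)CCN1CCC(NS(=O)(=O)c2cc(S(=O)(=O)c3ccccc3)ccc2C(F)(F)F)CC1` gives 200 nM in an assay on isolated protein for displacement of a labelled ligand from secreted frizzled-related protein 1 (Homo sapiens), read by fluorescence polarization, with a stated time of 30 min (on this read-out lower numbers stand for stronger inhibition and higher numbers for weaker inhibition), the second highest number among the three measured compounds; compound 1 `O=C(O)c1ccc(S(=O)(=O)N2CCC(NS(=O)(=O)c3cc(S(=O)(=O)c4ccccc4)ccc3C(F)(F)F)CC2)cc1` gives 20 nM and compound 2 `O=C(O)CCCC(=O)N1CCC(NS(=O)(=O)c2cc(S(=O)(=O)c3ccccc3)ccc2C(F)(F)F)CC1` gives 500 nM. Compound 4 `O=C(C1CCNCC1)N1CCC(NS(=O)(=O)c2cc(S(=O)(=O)c3ccccc3)ccc2C(F)(F)F)CC1` is not yet measured; it differs from compound 3 by (piperidin-4-yl)carbonyl in place of 3-hydroxy-3-methylbutyl on an amine nitrogen in a ring. Among the compounds with values here, the steps that bear on this change are a 2.5-fold lower number from compound 2 to compound 3 (0.40 log units; beyond the scatter), which compares an acyl with an alkyl group at the same nitrogen, and a 10-fold higher number from compound 1 to compound 3 (1.00 log units; beyond the scatter). Compound 4 returns to a carbonyl-linked group, as in compound 2, so a modest move toward a higher number than compound 3 is expected, a 1.5-fold higher number from compound 3 to compound 4 (0.18 log units; within the scatter). Compound 4 is therefore estimated at 300 nM, with a range of 100 nM to 1000 nM.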

Compound 4, half-maximal inhibitory concentration: 120 nM
Compound 4: middle estimate off by 2.5-fold (0.40 log units), on the high side, within the range that was stated.
By their numbers in this assay, from the lowest: compound 1; then compounds 4 and 3 (each within the scatter of the next); then compound 2.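

At this ring nitrogen, a carbonyl link does not by itself set the number: (piperidin-4-yl)carbonyl in place of 3-hydroxy-3-methylbutyl gives a 1.7-fold lower number from compound 3 to compound 4 (0.22 log units; within the scatter). With the carbonyl kept, the group on it does count, as piperidin-4-yl in place of 3-carboxypropyl gives a 4.2-fold lower number from compound 2 to compound 4 (0.62 log units; beyond the scatter). Compound 1 keeps the lowest number, with a 6.0-fold higher number from compound 1 to compound 4 (0.78 log units; beyond the scatter), and no measurement shown here explains any of these steps.

Open, as far as these compounds go, is whether the sulfonyl link or the carboxylic acid on the phenyl ring accounts for the number of compound 1. A (4-carboxyphenyl)carbonyl group or a plain phenylsulfonyl group at this nitrogen would separate the two.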